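Replacing a methylphenyl with pyridyl on a shared core

The source may hold more compounds than are shown below. What is called first, only, known or untested is meant among the compounds shown, and "the series" means these compounds.

Compound 1, `Cc1cnc(Nc2ccc(C(=O)Nc3c(C)cccc3C)cc2)nc1-c1ccccc1OC(F)(F)F`: in an assay on NIH3T3 cells for inhibition of Sonic hedgehog protein (Mus musculus), read by a luciferase reporter, with a stated time of 48 h (a higher number here means a weaker inhibitor, a lower number a stronger inhibitor), compound 1 gives > 500 nM, which is a limit of the assay and not a number.
Compound 2, `Cc1ccc(-c2nc(Nc3ccc(C(=O)Nc4c(C)cccc4C)cc3)ncc2C)cc1`: in this assay compound 2 gives > 500 nM, again only a limit.

Both values shown sit at the same limit, as the limit of > 500 nM in this assay, at which 2 of the 2 values shown sit, records, so neither compound has a number of its own and compound 2 cannot be placed above or below compound 1. Going by the values given here, the single measured step, a step that the two limits leave unreadable from compound 1 to compound 2, is therefore unreadable: the two limits leave its size and direction open.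

Compound 3, `Cc1cnc(Nc2ccc(C(=O)Nc3c(C)cccc3C)cc2)nc1-c1ccncc1`, differs from compound 2 by pyridin-4-yl in place of 4-methylphenyl on an aromatic carbon. No measured step bears on this change, since the only step shown is itself unreadable, and nothing in the measured pair tells how far a pyridin-4-yl would move the value. With both neighbours at the limit, the expectation for compound 3 in this assay is weak inhibition with a wide spread. Compound 3 is estimated at 1000 nM, with a range from 200 nM to 5000 nM. The step from compound 2 to compound 3 is expected to be a step that the limit leaves unreadable from compound 2 to compound 3, though with a limit as starting point this figure is only nominal.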

Compound 3, half-maximal inhibitory concentration: 0.54 nM
The estimate for compound 3 lay 1900-fold (3.27 log units) above the measured number; the measured number lies below the stated range.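

The aromatic carbon next to the ring nitrogen and ortho to a methyl group now proves sensitive to the group it carries, which the two earlier compounds could not show. In this assay, pyridin-4-yl in place of 4-methylphenyl gives an at least 920-fold lower number from compound 2 to compound 3 (2.96 log units; beyond the scatter), a change of one ring carbon with its methyl group for a ring nitrogen, and the entering group brings the only hydrogen-bond acceptor counted in this exchange. The same group in place of 2-(trifluoromethoxy)phenyl gives an at least 920-fold lower number from compound 1 to compound 3 (2.96 log units; beyond the scatter), so the result holds against both aryl groups shown, although each step gives only the smallest size the data allow, since compound 1 and compound 2 have no number of their own: the limit of > 500 nM in this assay, at which 2 of the 3 values shown sit.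

Compound 3 is the only compound shown with a nitrogen in this ring, so whether the low number depends on that atom, or on where it sits, remains open. Pyridin-3-yl, pyridin-2-yl, pyrimidin-5-yl or 4-methoxyphenyl at this carbon would test that, and the compounds shown give no reason for the size of the step.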